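The source may report more compounds than this note shows. Statements on the series, on what has been measured and on what is new or still open speak of the compounds shown alone.

Three compounds sharing one core were tested in a functional assay on U-251 cells (Homo sapiens) for inhibition, read by sulforhodamine B assay, with a stated time of 48 h; a higher number here means a weaker inhibitor of growth, a lower number a stronger inhibitor of growth. Compound 1 `Nc1cc(N)c2nc(-c3ccccc3)c(Oc3ccc(Cl)c(Cl)c3)nc2c1` gives 12000 nM in this assay. Compound 3 `CCOC(=O)[C@H](CCC(=O)O)NC(=O)c1ccc(Sc2nc3cc(N)cc(N)c3nc2-c2ccccc2)cc1`, which carries a longer side chain on the core, gives 14500 nM in this assay; this number and that of compound 1 lie within the usual scatter of each other, so no real difference between the two can be claimed. Compound 2 `CCOC(=O)[C@H](CCC(=O)O)NC(=O)c1ccc(CNc2nc3cc(N)cc(N)c3nc2-c2ccccc2)cc1`, with a related side chain, gave in this assay only a limit, < 100000 nM, and not a number. Of the two actual numbers, then, compound 1 has the lower one, and it sets the reference for what follows.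

Compound 4 `Nc1cc(N)c2nc(-c3ccccc3)c(Oc3ccc(F)cc3)nc2c1` differs from compound 1 in a single place: 4-fluorophenyl in place of 3,4-dichlorophenyl on an oxygen on an aromatic ring. Within the data shown here, no pair of measured compounds shows what such a swap does, so the size of the change cannot be read from a measured step. On that basis the step in this assay is expected to be small, in no clear direction and probably not beyond the scatter. The step that this estimate means, a 1.3-fold higher number from compound 1 to compound 4 (0.10 log units; within the scatter), is expected to stay within the scatter. Compound 4 is therefore estimated to give about 15000 nM in this assay, most likely between 5000 nM and 50000 nM.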

Compound 4, concentration for 50% growth inhibition: 23400 nM
Compound 4: middle estimate off by 1.6-fold (0.19 log units), on the low side; low and high end bracket the measured number.
By their numbers in this assay, from the lowest: compounds 1, 3 and 4 (each within the scatter of the next).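

Among these compounds, replacing the group on the oxygen gives the first measured step: in this assay, the change produces a 2.0-fold higher number from compound 1 to compound 4 (0.29 log units; within the scatter). This step lies within the usual scatter and cannot be called a real difference. At this place, on an oxygen on an aromatic ring, 4-fluorophenyl and 3,4-dichlorophenyl cannot be told apart by this read-out, and the chlorine atoms of compound 1 are not needed to give a number of this size. Nothing measured in this set bears on why the two groups behave so alike.

Among the compounds shown here, the single step leaves open whether any group at this place would move the number beyond the scatter, for example an unsubstituted phenyl, a phenyl carrying an amine or a carboxylic acid, or a small methyl in place of the ring. It also leaves open whether the same swap would behave alike on a compound with a longer chain, such as the ethyl ester side chain of compound 3, at this place on the shared core.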